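The source may report more compounds than this note shows. Statements on the series, on what has been measured and on what is new or still open speak of the compounds shown alone.

Measured so far in an assay on MCF7 cells for inhibition of Serine-protein kinase ATM (Homo sapiens), read by immunofluorescence, with a stated time of 1 h; a lower number here means a stronger inhibitor, a higher number a weaker inhibitor:
- compound 1 `Nc1nc(-c2ccccc2)nn1-c1ncnc2ccccc12`: > 40000 nM, a limit of the assay
- compound 2 `COCCOc1cc2c(-n3nc(-c4ccccn4)nc3N)ncnc2cc1OC`: 1200 nM
- compound 3 `COc1cc2ncnc(-n3nc(-c4ccccn4)nc3N)c2cc1OCCCNC(=O)OC(C)(C)C`: 900 nM

Compound 3 gives the lowest of the two numbers in this assay; its nearest neighbour is compound 2, and the step of a 1.3-fold lower number from compound 2 to compound 3 (0.12 log units; within the scatter) lies within the scatter, so the two cannot be ordered. Compound 1 sits at the assay limit of > 40000 nM in this assay, at which 1 of the 3 values shown sits, and gives no number to compare.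

Compound 4 `COc1cc2ncnc(-n3nc(-c4ccccn4)nc3N)c2cc1OCCCNC(=O)C(F)(F)F` differs from compound 3 by trifluoromethyl in place of tert-butoxy on a carbonyl carbon whose other neighbour is an amide-type nitrogen. Among the compounds with values here, only one measured step is on the same side chain, from compound 2 to compound 3, and that exchange of ((tert-butoxycarbonyl)amino)methyl for methoxy moved the number by a 1.3-fold lower number from compound 2 to compound 3 (0.12 log units; within the scatter), within the scatter. The present change is smaller in heavy-atom count and sits on the carbonyl carbon of that same group, so no step beyond the scatter is expected in this assay in either direction; the expected step is no change at the digits printed from compound 3 to compound 4 (within the scatter).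

Compound 4 is therefore estimated at 900 nM, with a range of 400 nM to 2000 nM.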

Compound 4, half-maximal inhibitory concentration: 2900 nM
Beside the measured number, compound 4's estimate is 3.2-fold (0.51 log units) below it; measured number above the stated range.
By their numbers in this assay, from the lowest: compounds 3 and 2 (each within the scatter of the next); then compound 4. At a limit, above all of these: compound 1.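

In this assay, within the data shown here, the carbonyl end of this side chain gives the first one-place change on the chain that reads beyond the scatter: trifluoromethyl in place of tert-butoxy on a carbonyl carbon whose other neighbour is an amide-type nitrogen gives a 3.2-fold higher number from compound 3 to compound 4 (0.51 log units; beyond the scatter) as a modest step. The methoxy-ended chain of compound 2 offers a second reference, with a 2.4-fold higher number from compound 2 to compound 4 (0.38 log units; beyond the scatter) also modest and beyond the scatter, whereas compound 2 and compound 3 could not be ordered despite their quite different chain ends, so this position does respond to the group on the carbonyl, though only to a small degree across these three compounds. Nothing among the data shown gives a cause for this step.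

The compounds shown leave open whether the rise follows from the loss of tert-butoxy or from the entry of trifluoromethyl, a question that a plain acetyl or a tert-butyl amide on the same chain would help to separate. Also open, going by these compounds, is how the number responds to a free primary amine or a carboxylic acid at the chain end, or to a longer chain.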